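Aryl swap on a methylpiperidine analogue in cytotoxicity

The compounds below may be only part of what the source reports. "The series", "measured", "known", "first", "only" and "open" are said of these compounds alone.

Measured compounds:
Compound 1 `COc1cc2c(Oc3ccc(NC(=O)N/N=C/c4ccc(C(F)(F)F)cc4)cc3F)ccnc2cc1OCCCN1CCCCC1`: 630 nM
Compound 2 `COc1cc2c(Oc3ccc(NC(=O)N/N=C/c4ccc(Cl)cc4Cl)cc3F)ccnc2cc1OCCCN1CCCCC1`: 460 nM
Compound 3 `COc1cc2c(Oc3ccc(NC(=O)N/N=C/c4ccc(C(F)(F)F)cc4)cc3F)ccnc2cc1OCCCN1CCC(C)CC1`: 1000 nM

In a functional assay on MKN-45 cells (Homo sapiens) for cytotoxicity, read by MTT assay, with a stated time of 72 h (a lower number here means a stronger inhibitor, a higher number a weaker inhibitor), compound 1 gives 630 nM, compound 2 gives 460 nM and compound 3 gives 1000 nM. The change 2,4-dichlorophenyl in place of 4-(trifluoromethyl)phenyl on a carbon with a double bond to nitrogen gave a 1.4-fold lower number from compound 1 to compound 2 (0.14 log units; within the scatter). The core of compound 3 differs from that of compound 1 by methyl in place of hydrogen on a saturated ring carbon, with a 1.6-fold higher number from compound 1 to compound 3 (0.20 log units; within the scatter). Compound 4 `COc1cc2c(Oc3ccc(NC(=O)N/N=C/c4ccc(Cl)cc4Cl)cc3F)ccnc2cc1OCCCN1CCC(C)CC1` is not yet measured; it carries the change 2,4-dichlorophenyl in place of 4-(trifluoromethyl)phenyl on a carbon with a double bond to nitrogen on the core of compound 3, the same change as from compound 1 to compound 2, on the same kind of carbon. Because that step gave a 1.4-fold lower number from compound 1 to compound 2 (0.14 log units; within the scatter), the expected step in this assay is a 1.4-fold lower number from compound 3 to compound 4 (0.15 log units; within the scatter), which is within the scatter. Compound 4 is therefore estimated at 700 nM, between 350 nM and 1400 nM.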

Compound 4, half-maximal inhibitory concentration: 350 nM
For compound 4 the middle estimate is 2.0-fold (0.30 log units) above the measured one, and the stated range covers the measured number.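

In this assay, 2,4-dichlorophenyl in place of 4-(trifluoromethyl)phenyl gave a 2.9-fold lower number from compound 3 to compound 4 (0.46 log units; beyond the scatter), and the two steps for this change cannot be told apart: the same change on two cores in this assay, a 1.4-fold lower number (0.14 log units; within the scatter) from compound 1 to compound 2 and a 2.9-fold lower number (0.46 log units; beyond the scatter) from compound 3 to compound 4, 2.1-fold (0.32 log units) apart, within the scatter of two such steps. Methyl in place of hydrogen on a saturated ring carbon gave a 1.3-fold lower number from compound 2 to compound 4 (0.12 log units; within the scatter), and this change likewise shows no clear dependence on the core: the same change on two cores in this assay, a 1.6-fold higher number (0.20 log units; within the scatter) from compound 1 to compound 3 and a 1.3-fold lower number (0.12 log units; within the scatter) from compound 2 to compound 4, 2.1-fold (0.32 log units) apart, within the scatter of two such steps. Both changes thus carried across this one pair of cores within the scatter, but that does not show they would carry to other cores in the series.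

The compounds shown leave open whether a nitrile or a methoxy group on the aryl ring, or a morpholine in place of the saturated ring, would behave the same way.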